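A few compounds are considered here, and "the series" means these few. Any claim that something is new, unique, unknown or untested is made for them only; others in the source may bear on it.

Compound 1 `CCOC(=O)C1=Cc2ccc(OC)cc2OC1c1cc(OC)c(OC)c(OC)c1` gives 25000 nM in a functional assay for inhibition of nuclear factor NF-kappa-B complex (Homo sapiens) (on this read-out higher numbers stand for weaker inhibition and lower numbers for stronger inhibition), the highest of the three numbers recorded, although all three sit within the scatter of one another. Compound 2 `COc1ccc2c(c1)OC(c1cc(OC)c(OC)c(OC)c1)C(C(=O)OC(C)(C)C)=C2` gives 14100 nM and compound 3 `COc1ccc2c(c1)OC(c1cc(OC)c(OC)c(OC)c1)C(C(=O)OCCc1ccccc1)=C2` gives 16200 nM. The steps of a 1.8-fold lower number from compound 1 to compound 2 (0.25 log units; within the scatter) and a 1.5-fold lower number from compound 1 to compound 3 (0.19 log units; within the scatter) each alter only the group on the oxygen next to the carbonyl group, as does a 1.1-fold higher number from compound 2 to compound 3 (0.06 log units; within the scatter), and none reaches beyond the scatter. Compound 4 `COc1ccc2c(c1)OC(c1cc(OC)c(OC)c(OC)c1)C(C(=O)O)=C2` differs from compound 1 by hydrogen in place of ethyl on an oxygen next to a carbonyl group, the same place once more. All three earlier steps at that place having stayed within the scatter, the number for compound 4 is expected to sit close by, a step of a 1.2-fold higher number from compound 1 to compound 4 (0.08 log units; within the scatter) of no real size. The estimate for compound 4 is 30000 nM, with a range from 10000 nM to 90000 nM.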

Compound 4, half-maximal inhibitory concentration: > 50000 nM
Compound 4 gave a limit, no number; the forecaster's own chance of this, stated with the estimate: 20%; at least 1.6-fold (0.22 log units) between middle value and limit.
By their numbers in this assay, from the lowest: compounds 2, 3 and 1 (each within the scatter of the next). At a limit, above all of these: compound 4.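

Compound 4 gives only a limit, not a number: the limit of > 50000 nM in this assay, at which 1 of the 4 values shown sits. This position does respond to change after all: with hydrogen in place of phenethyl or tert-butyl, the result is an at least 3.0-fold higher number from compound 3 to compound 4 (0.48 log units; beyond the scatter) and an at least 3.5-fold higher number from compound 2 to compound 4 (0.54 log units; beyond the scatter), both beyond the scatter, whereas swaps among the three larger groups stayed within it. Against ethyl the result is an at least 2.0-fold higher number from compound 1 to compound 4 (0.30 log units; that floor lies within the scatter), and that floor lies within the scatter, so this step alone shows no clear loss.

The limit leaves the true size of all these steps open. Also open, on these data alone, is what a methyl group on this oxygen, or an amide in place of the carboxy group, would give.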